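The compounds below may be only part of what the source reports. "The series", "measured", "known", "first", "only" and "open" are said of these compounds alone.

Measured so far in an ADME assay on GES1 cells (Homo sapiens) for cytotoxicity, read by MTT assay, with a stated time of 24 h; on this read-out higher numbers stand for lower toxicity in this test and lower numbers for higher toxicity in this test:
compound 1 `O=c1[nH]cc(S(=O)(=O)Nc2ccccc2-c2cn(-c3ccccc3Cl)nn2)c(=O)[nH]1` gives 20800 nM
compound 2 `O=c1[nH]cc(S(=O)(=O)Nc2ccccc2-c2cn(-c3cccc(Cl)c3)nn2)c(=O)[nH]1` gives > 100000 nM
compound 3 `O=c1[nH]cc(S(=O)(=O)Nc2cccc(-c3cn(-c4ccccc4)nn3)c2)c(=O)[nH]1` gives 22500 nM

Compound 3 stands at the higher of the two numbers reported in this assay, yet its value and that of compound 1 lie within the scatter of each other, so no order between the two can be read. For compound 2 the assay reports only a limit, > 100000 nM, and not a number. Going by the values given here, the one measured step, an at least 4.8-fold higher number from compound 1 to compound 2 (0.68 log units; beyond the scatter), concerns a chlorophenyl group moved on an aromatic nitrogen; it carries the value to the limit, where the limit of > 100000 nM in this assay, at which 1 of the 3 values shown sits, marks how many values sit.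

Compound 4 `O=c1[nH]cc(S(=O)(=O)Nc2cccc(-c3cn(-c4ccc(F)cc4)nn3)c2)c(=O)[nH]1` differs from compound 3 by fluoro in place of hydrogen on an aromatic carbon. Among the compounds with values here, no measured step introduces a fluoro group, and the step from compound 1 to compound 2 alters a different part of the molecule, so it offers no direct guide. With nothing pointing either way, compound 4 is expected to sit close to compound 3, with a 1.1-fold higher number from compound 3 to compound 4 (0.05 log units; within the scatter) as the expected step. Compound 4 is therefore estimated at 25000 nM in this assay, within a range from 10000 nM to 70000 nM.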

Compound 4, half-maximal cytotoxic concentration: "not toxic" (no number reported)
For compound 4 the study gives words and no number; there is nothing to compare the estimate with.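

In this assay, going by these compounds alone, compound 4 is reported only as not toxic, without a number, so no step from compound 3 to compound 4 can be read, and nothing measured here bears on that wording. The compounds shown leave open whether going from phenyl to 4-fluorophenyl changes the number at all.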